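The compounds below may be only part of what the source reports. "The series", "measured", "known", "first", "only" and "open" are said of these compounds alone.

Compound 1 `COc1cc2ncnc(Nc3ccc(F)c(Cl)c3)c2cc1OCCn1ccnc1[N+](=O)[O-]` and compound 2 `COc1cc2ncnc(Nc3ccc(F)c(Cl)c3)c2cc1OCCCCn1ccnc1[N+](=O)[O-]` share one core and differ only in the length of the saturated chain that joins the aromatic oxygen to the nitroimidazole. In a functional assay on HT-29 cells (Homo sapiens) for cytotoxicity, read by sulforhodamine B assay, with a stated time of 72 h (a higher number here means a weaker inhibitor, a lower number a stronger inhibitor), compound 1 gives only a limit, > 50000 nM. In this assay, among the measured compounds shown here, compound 2 gives 2210 nM, the only number among the values shown. The other value shown, that of compound 1, is a limit, which matches the evidence that (the limit of > 50000 nM in this assay, at which 1 of the 2 values shown sits). The step of an at least 22-fold lower number from compound 1 to compound 2 (1.35 log units; beyond the scatter) shows that lengthening the chain here mattered a great deal. Compound 3 `COc1cc2ncnc(Nc3ccc(F)c(Cl)c3)c2cc1OCCCCCn1ccnc1[N+](=O)[O-]` takes the same direction one bond further: (2-nitro-1H-imidazol-1-yl)methyl in place of 2-nitro-1H-imidazol-1-yl on a saturated chain carbon, four bonds along the chain from an oxygen on an aromatic ring. For the measured compounds named here, only this single lengthening step bears on the change, so the expectation for compound 3 is a smaller step in the same direction, or none beyond the scatter, as the step of a 1.5-fold lower number from compound 2 to compound 3 (0.17 log units; within the scatter). Compound 3 is therefore estimated at 1500 nM in this assay, within a range of 500 nM to 5000 nM.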

Compound 3, half-maximal inhibitory concentration: 17600 nM
Estimate against measurement, compound 3: 12-fold (1.07 log units) below; measured number above the stated range.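

Lengthening the chain once more does not continue the earlier gain in this assay: the result is an 8.0-fold higher number from compound 2 to compound 3 (0.90 log units; beyond the scatter), which makes compound 2 the strongest of the three compounds and shows that the response to chain length at this position changes direction. Even so, the longest chain shown retains part of the gain over the shortest, with an at least 2.8-fold lower number from compound 1 to compound 3 (0.45 log units; beyond the scatter). Compound 1 has a limit rather than a number, so this step gives only a minimum size: the limit of > 50000 nM in this assay, at which 1 of the 3 values shown sits.

On these data alone, it remains open how a propyl chain would compare with the chain of compound 2, and whether a longer chain than that of compound 3 would raise the number further. Also open, as far as these compounds go, is whether an amine in place of the nitro group would preserve the same dependence on chain length.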